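The compounds below may be only part of what the source reports. "The series", "measured", "known", "first", "only" and "open" are said of these compounds alone.

Measured compounds:
Compound 1 `CCCc1nc2cccc(C(=O)O)c2n1Cc1ccc(-c2ccccc2-c2noc(O)n2)cc1`: 88%
Compound 2 `CCCCc1nc2cccc(C(=O)O)c2n1Cc1ccc(-c2ccccc2-c2noc(O)n2)cc1`: 64%
Compound 3 `COc1nc2cccc(C(=O)O)c2n1Cc1ccc(-c2ccccc2-c2noc(O)n2)cc1`: 88%

All three numbers come from a functional assay on the whole organism for inhibition, with Rattus norvegicus as the target, with a stated time of 7 h, at a dose of 1 mg/kg by the oral route; a lower number here means less inhibition, a higher number more inhibition at the dose given (going by the name of the read-out). Compound 3 stands level with compound 1 (no change at the digits printed from compound 1 to compound 3 (within the scatter)), the two together forming the top of the set, while compound 2 sits apart from them (a number 24 percentage points higher from compound 2 to compound 3 (beyond the scatter)).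

Compound 4 `CCCOc1nc2cccc(C(=O)O)c2n1Cc1ccc(-c2ccccc2-c2noc(O)n2)cc1` differs from compound 3 by ethyl in place of hydrogen on a saturated chain carbon bound to an oxygen on an aromatic ring; cut one bond further out the difference reads methoxy to propoxy. Among the measured compounds shown here, no measured pair shows exactly this change. The nearest comparison is the growth of the chain on the aromatic carbon in the shared core: methyl in place of hydrogen on a saturated chain carbon, three bonds along the chain from an aromatic carbon, which gave a number 24 percentage points lower from compound 1 to compound 2 (beyond the scatter). The move from butyl to methoxy on that carbon gave a number 24 percentage points higher from compound 2 to compound 3 (beyond the scatter), while propyl and methoxy sat level. Taken together, adding chain length here has been neutral once and costly once. Compound 4 is therefore expected to fall somewhat, by an amount comparable to the step from compound 1 to compound 2, with a range that still allows no change. The expected step is a number 18 percentage points lower from compound 3 to compound 4 (beyond the scatter). Compound 4 is estimated at 70%, between 50% and 88%.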

Compound 4, a percentage reported as inhibition, in the whole organism at one dose (the size of the read-out at that dose, not a potency): 100%
The estimate for compound 4 lay 30 percentage points below the measured number; the whole stated range lies below it.
By their numbers in this assay, from the lowest: compound 2; then compounds 1 and 3 (each within the scatter of the next); then compound 4.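

In this assay, lengthening the chain on the oxygen does not carry the cost seen when the all-carbon chain grew: ethyl in place of hydrogen on the saturated chain carbon bound to an oxygen on an aromatic ring gives a number 12 percentage points higher from compound 3 to compound 4 (beyond the scatter) whereas the earlier growth gave a number 24 percentage points lower from compound 1 to compound 2 (beyond the scatter). Propoxy also stands above both carbon chains on this aromatic carbon, with propoxy in place of propyl giving a number 12 percentage points higher from compound 1 to compound 4 (beyond the scatter) and propoxy in place of butyl giving a number 36 percentage points higher from compound 2 to compound 4 (beyond the scatter), although compound 3 goes against any general advantage of an oxygen-linked chain, since methoxy and propyl sit level in compound 3 and compound 1. Nothing available explains why the oxygen-linked and all-carbon chains behave differently here.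

The compounds shown leave open whether the gain extends to ethoxy, butoxy or a longer oxygen-linked chain, or whether it survives branching, as in isopropoxy. Because each number comes from one dose at one stated time, they also leave open how these compounds would rank at a lower dose or at another time.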